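The compounds below may be only part of what the source reports. "The series", "measured", "known", "first", "only" and "open" are said of these compounds alone.

Of the two compounds measured in a functional assay on MIA PaCa-2 cells (Homo sapiens) for inhibition, read by MTT assay, with a stated time of 72 h (a lower number here means a stronger inhibitor of growth, a higher number a weaker inhibitor of growth), compound 2 `O=S(=O)(NCCCNCc1cccc2ccccc12)c1cc(C(F)(F)F)cc(C(F)(F)F)c1` gives the lowest number, 2800 nM. Among the compounds with values here, its only measured neighbour, compound 1 `O=S(=O)(NCCCNCc1ccc(Cl)c(C(F)(F)F)c1)c1cc(C(F)(F)F)cc(C(F)(F)F)c1`, gives 7400 nM, the step between them being a 2.6-fold lower number from compound 1 to compound 2 (0.42 log units; beyond the scatter). Compound 3 `COc1ccc(CNCCCNS(=O)(=O)c2cc(C(F)(F)F)cc(C(F)(F)F)c2)cc1` is not yet measured and differs from compound 2 by 4-methoxyphenyl in place of naphthalen-1-yl on a saturated chain carbon bound to an amine nitrogen. That one step at the same position bears on this change and was modest, so a modest move back upward is expected, a 1.8-fold higher number from compound 2 to compound 3 (0.25 log units; within the scatter). Compound 3 is therefore estimated at 5000 nM in this assay, with a range from 2000 nM to 13000 nM.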

Compound 3, concentration for 50% growth inhibition: 2500 nM
Compound 3: the middle estimate sits 2.0-fold (0.30 log units) above what was measured; low and high end bracket the measured number.
By their numbers in this assay, from the lowest: compounds 3 and 2 (each within the scatter of the next); then compound 1.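

Here the larger naphthalen-1-yl and the smaller 4-methoxyphenyl cannot be told apart in this assay, with a 1.1-fold lower number from compound 2 to compound 3 (0.05 log units; within the scatter), so a second aromatic ring is not required on this saturated chain carbon bound to an amine nitrogen. The gain seen earlier over 4-chloro-3-(trifluoromethyl)phenyl also holds for a quite different group, with a 3.0-fold lower number from compound 1 to compound 3 (0.47 log units; beyond the scatter). No measurement here explains either result.
On these data alone, what remains open is whether the methoxy group of compound 3 contributes anything, which an unsubstituted phenyl would test. A pyridine ring or a longer chain at this position is also untested territory.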